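A Wider Swap at the Carbonyl Carbon

A few compounds are considered here, and "the series" means these few. Any claim that something is new, unique, unknown or untested is made for them only; others in the source may bear on it.

In an ADME assay on microsomes from liver (Homo sapiens) for metabolic stability, read by LC-MS, using NADPH, with a stated time of 30 min, tested at 0.1 uM (a higher number here means that more of the compound is left, a lower number that less of the compound is left), compound 1 `C[C@@]1(c2cc(NC(=O)c3cnc(OCF)cn3)ccc2F)C=C(CF)OC(N)=N1` gives 86% and compound 2 `C[C@@]1(c2cc(NC(=O)c3cnc(C(F)F)cn3)ccc2F)C=C(CF)OC(N)=N1` gives 84%, so the two cannot be told apart. For the measured compounds named here, the only measured step is a number 2 percentage points lower from compound 1 to compound 2 (within the scatter), and it comes from placing difluoromethyl in place of fluoromethoxy on an aromatic carbon. Compound 3 `C[C@@]1(c2cc(NC(=O)c3ccc(C#N)cn3)ccc2F)C=C(CF)OC(N)=N1` differs from compound 2 as follows: 5-cyanopyridin-2-yl in place of 5-(difluoromethyl)pyrazin-2-yl on a carbonyl carbon. In words, 5-cyanopyridin-2-yl stands in place of 5-(difluoromethyl)pyrazin-2-yl on a carbonyl carbon, so the whole aromatic ring unit is exchanged. Going by the values given here, the measured step covers only a swap of one group, and no measured compound shows what exchanging this ring does, so it offers weak guidance. The expected result is a number 1 percentage points lower from compound 2 to compound 3 (within the scatter), with no shift beyond the scatter in either direction. The estimated value for compound 3 is 83%, with a range of 70% to 93%.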

Compound 3, percent of the compound remaining: 88%
For compound 3 the middle estimate is 5 percentage points below the measured one, and the stated range covers the measured number.
By their numbers in this assay, from the lowest: compounds 2, 1 and 3 (each within the scatter of the next).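

In this assay, for the compounds shown here, the earlier step changed only one group on the ring, whereas this change exchanges the whole aromatic ring unit on the carbonyl carbon. Even so, it gives a number 4 percentage points higher from compound 2 to compound 3 (within the scatter) and, against the fluoromethoxy partner, a number 2 percentage points higher from compound 1 to compound 3 (within the scatter). Across these three compounds, a ring with 1 hetero atom carrying a nitrile therefore cannot be told apart from a ring with 2 hetero atoms carrying either fluorinated group. Nothing available gives a reason for this flat result.

The compounds shown leave open whether the same holds for a ring unit carrying an amine or a carboxylic acid, or for a plain phenyl ring. They also leave open whether a longer chain in place of the nitrile would keep the number within the scatter.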